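The compounds below may be only part of what the source reports. "The series", "measured", "known", "first", "only" and "open" are said of these compounds alone.

Of the compounds shown here, three have been read so far in an ADME assay on MRC5 cells (Homo sapiens) for cytotoxicity (on this read-out higher numbers stand for weaker inhibition and lower numbers for stronger inhibition), and none of them gave a number. Compound 1 `N#CCN(CCCCN1CCCC1)C(=O)OCc1ccccc1` returned only a limit of the assay, > 64000 nM. Compound 2 `N=C(N)NCCC[C@@H](/C=C/S(=O)(=O)c1ccccc1)NC(=O)OCc1ccccc1` also returned only a limit, > 64000 nM. Compound 3 `N#CCN(C(=O)OCc1ccccc1)C1CCNCC1` did the same, with a limit of > 64000 nM. Compound 1 therefore stands with the other two at one place: the limit of > 64000 nM in this assay, at which 3 of the 3 values shown sit.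

Compound 4 `N#CCN(CCCCn1ccnc1)C(=O)OCc1ccccc1` has not yet been measured. It keeps the core of compound 1 and differs from it in one place: 1H-imidazol-1-yl in place of pyrrolidin-1-yl on a saturated chain carbon, four bonds along the chain from an amide-type nitrogen. For the measured compounds named here, no measured pair shows what this exchange does in this assay, so the expectation is for no step beyond the scatter, with only a slight chance of a move towards stronger inhibition. This expectation rests on the limit for compound 1, > 64000 nM. The expected step is an at least 1.0-fold lower number from compound 1 to compound 4 (0.02 log units; that floor lies within the scatter). For compound 4 the estimated value is 60000 nM, with an expected range from 30000 nM to 64000 nM.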

Compound 4, half-maximal inhibitory concentration: > 64000 nM
Compound 4: a limit, no number; the forecaster's own chance of this, stated with the estimate: 75%; middle value at least 1.0-fold (0.02 log units) away from the limit.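

Compound 1 and compound 4 both gave only limits in this assay, so no step can be read for 1H-imidazol-1-yl in place of pyrrolidin-1-yl. The compounds shown leave open which change, if any, would give a number rather than a limit: the limit of > 64000 nM in this assay, at which 4 of the 4 values shown sit.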